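The source may hold more compounds than are shown below. What is called first, only, known or untested is meant among the compounds shown, and "the series" means these compounds.

Working notes on the series, with all numbers taken from a functional assay on K562 cells (Homo sapiens) for inhibition, read by MTT assay, with a stated time of 48 h (on this read-out higher numbers stand for weaker inhibition and lower numbers for stronger inhibition), as the single read-out. Compound 1 `C[C@H](NC(=O)c1cccc(-c2cncc(C(=O)NC3CC3)c2)c1)C(=O)Nc1ccc(Cl)c(C(F)(F)F)c1` stands level with compound 2 `CCN(CC)C(=O)c1cncc(-c2cccc(C(=O)N[C@@H](C)C(=O)Nc3ccc(Cl)c(C(F)(F)F)c3)c2)c1` within the scatter (compound 1 at 15100 nM, compound 2 at 29900 nM). Compound 3 `O=C(NC1CC1)c1cncc(-c2ccc(C(=O)N[C@H]3CN[C@@H](C(=O)Nc4ccc(Cl)c(C(F)(F)F)c4)C3)cc2)c1` gives a higher number than compound 1, beyond the scatter (compound 3 at 65300 nM).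

Compound 4 `C[C@H](NC(=O)c1cccc(-c2ccc(N)nc2)c1)C(=O)Nc1ccc(Cl)c(C(F)(F)F)c1` is still unmeasured and differs from compound 1 as follows: 6-aminopyridin-3-yl in place of 5-(cyclopropylcarbamoyl)pyridin-3-yl on an aromatic carbon. For the measured compounds named here, one measured step bears on this: a 2.0-fold higher number from compound 1 to compound 2 (0.30 log units; within the scatter) came from diethylamino in place of cyclopropylamino on a carbonyl carbon of the group that leaves here, and it stayed within the scatter. Going by the values given here, no measured compound lacks that carbonyl, so the support is thin. A step beyond the scatter is not expected in this assay in either direction. The expected change is a 1.2-fold higher number from compound 1 to compound 4 (0.08 log units; within the scatter) and has no firm direction. In this assay the estimate for compound 4 is 18000 nM with an expected range of 7000 nM to 45000 nM (estimated, not measured).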

Compound 4, half-maximal inhibitory concentration: 8090 nM
Compound 4: the middle estimate sits 2.2-fold (0.35 log units) above what was measured; low and high end bracket the measured number.
By their numbers in this assay, from the lowest: compounds 4, 1 and 2 (each within the scatter of the next, the first and the last beyond it); then compound 3.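

In this assay the exchange at this aromatic carbon gives a 1.9-fold lower number from compound 1 to compound 4 (0.27 log units; within the scatter) and so stays within the scatter. The earlier step changed only the amine part of the carbamoyl group, whereas here the whole 5-(cyclopropylcarbamoyl)pyridin-3-yl leaves with its carbonyl and three-membered ring, and the smaller 6-aminopyridin-3-yl enters, so the number holds without that carbonyl. No evidence is at hand that bears on this result.

The compounds shown do not separate the loss of the carbamoyl group from the gain of the amino group. On these data alone, whether a carboxylic acid or a longer chain on the amine at this aromatic carbon would also stay within the scatter remains open.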